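This account rests on a few compounds, and the source may have more. Where it says the series, first, only, none or still open, it means among the compounds named here.

Working notes on the cyclopropane carboxylic acid series, agonism at the mouse receptor.

The read-out is a functional assay on cells for agonist activity at Free fatty acid receptor 1 (Mus musculus), read by FLIPR and calcium flux, with a stated time of 5 min; on this read-out lower numbers stand for an effect already at smaller amounts and higher numbers for an effect only at larger amounts of compound. Compound 1 `Cc1ccc(-n2nc(C)c3c(F)cc(-c4ccc([C@H]5C[C@@H]5C(=O)O)cc4)cc32)cc1` carries a methyl group on its core and a 4-methylphenyl group on the ring nitrogen; in this assay compound 1 reaches only the limit of > 100000 nM, not a number. Compound 2 `COc1nn(-c2ccccn2)c2cc(-c3ccc([C@H]4C[C@@H]4C(=O)O)cc3)cc(F)c12` carries a methoxy group on the core and a pyridin-2-yl group on the ring nitrogen; in this assay compound 2 likewise reaches only the limit of > 100000 nM, not a number. Going by the values given here, compound 2 therefore stands at the limit of > 100000 nM in this assay, at which 2 of the 2 values shown sit, so no step between measured compounds can be sized here.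

Compound 3 `COc1nn(-c2ccc(C)cc2)c2cc(-c3ccc([C@H]4C[C@@H]4C(=O)O)cc3)cc(F)c12` is the next entry: 4-methylphenyl in place of pyridin-2-yl on an aromatic nitrogen. Compound 1 already combines a 4-methylphenyl group on that nitrogen with an inactive read-out, and compound 2 sits at the limit, so no movement beyond the scatter is expected. For compound 3 the expected outcome in this assay is 100000 nM, with a range from 30000 nM to 300000 nM. The step expected from compound 2 to compound 3 is a number no higher from compound 2 to compound 3 (the limit leaves the size open), none beyond the scatter, most likely again a limit rather than a number.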

Compound 3, half-maximal effective concentration in the Free fatty acid receptor 1 assay: > 100000 nM
Compound 3 was reported as a limit; the forecaster's own chance of this, stated with the estimate: 85%; the middle value sits exactly at the limit.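

In the Free fatty acid receptor 1 assay compound 3 gives > 100000 nM, which is a limit and not a number. Compound 1, compound 2 and compound 3 all stand at one limit in the Free fatty acid receptor 1 assay, so neither step to compound 3 can be read: the limit of > 100000 nM in the Free fatty acid receptor 1 assay, at which 3 of the 3 values shown sit.

In a physicochemical assay for lipophilicity, using the shake flask method, measured as octanol-water partition, with a stated time of 30 min, at pH 7.4 (on this read-out lower numbers stand for lower lipophilicity and higher numbers for higher lipophilicity), compound 2 gives 3.8. In the physicochemical assay compound 3 gives > 4.2, which is a limit and not a number.

The compounds shown leave open which change on the shared core, if any, would give a number rather than a limit in the Free fatty acid receptor 1 assay, and how large the steps among these three compounds are.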